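Replacing 2,5-dichlorobenzyl with 2,5-dimethoxybenzyl in compound 1

The compounds below may be only part of what the source reports. "The series", "measured", "known", "first", "only" and "open" are said of these compounds alone.

Within the data shown here, in a functional assay on SK-BR-3 cells (Homo sapiens) for antiproliferative activity, read by MTT assay, with a stated time of 48 h (on this read-out higher numbers stand for weaker inhibition and lower numbers for stronger inhibition), compound 1 `CN(c1ccc(NC(=O)c2ccc(I)cc2)cc1OCc1cc(Cl)ccc1Cl)S(C)(=O)=O` gives 660 nM, the lower of the two numbers measured so far, and compound 2 `CN(c1ccc(NC(=O)c2ccc3ccccc3c2)cc1OCc1cc(Cl)ccc1Cl)S(C)(=O)=O` gives 2210 nM. The next compound to be tested is compound 3 `COc1ccc(OC)c(COc2cc(NC(=O)c3ccc(I)cc3)ccc2N(C)S(C)(=O)=O)c1`. It keeps the 4-iodophenyl group of compound 1 and has 2,5-dimethoxyphenyl in place of 2,5-dichlorophenyl on a saturated chain carbon bound to an oxygen on an aromatic ring. The counted difference is 2,5-dimethoxyphenyl in place of 2,5-dichlorophenyl on a saturated chain carbon bound to an oxygen on an aromatic ring.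

Among the measured compounds shown here, only one measured step is available, a 3.3-fold higher number from compound 1 to compound 2 (0.52 log units; beyond the scatter). It lies at a carbonyl carbon, not at the place that changes here, so it offers a guide to size but none to direction. For the measured compounds named here, no measurement yet tests any change at the 2,5-dichlorophenyl group. Since compound 1 already holds the lowest number at 660 nM, a modest move towards weaker inhibition seems more likely than a gain, though this is only a tentative expectation. The step expected in this assay is a 2.3-fold higher number from compound 1 to compound 3 (0.36 log units; beyond the scatter). The estimated value for compound 3 is 1500 nM, within an expected range of 450 nM to 5000 nM.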

Compound 3, half-maximal inhibitory concentration: 1.21 nM
Compound 3: middle estimate off by 1200-fold (3.09 log units), on the high side; the whole stated range lies above it.
By their numbers in this assay, from the lowest: compound 3; then compound 1; then compound 2.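

The group on the saturated chain carbon bound to an oxygen on an aromatic ring proves to be a decisive point of the series: in this assay, 2,5-dimethoxyphenyl in place of 2,5-dichlorophenyl gives a 550-fold lower number from compound 1 to compound 3 (2.74 log units; beyond the scatter), with the 4-iodophenyl group and the rest of the structure unchanged. This step is far larger than the only earlier one, a 3.3-fold higher number from compound 1 to compound 2 (0.52 log units; beyond the scatter), so the earlier change at the carbonyl carbon gave no sign of how much this position could matter. The data show the size and direction of this exchange, but no measurement of any property bears on why it has such an effect.

A single pair cannot show whether the gain needs both methoxy groups or depends on the replacement of both chlorines, and ethoxy, hydroxyl or amino groups on the benzyl ring are not among the compounds shown. As far as these compounds go, it also remains open whether 2,5-dimethoxybenzyl would bring a similar step with naphthalen-2-yl on the carbonyl carbon.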